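A few compounds are considered here, and "the series" means these few. Any claim that something is new, unique, unknown or untested is made for them only; others in the source may bear on it.

Of the compounds shown here, three sharing one core have been tested in an assay on a protein complex for binding affinity to Neuronal acetylcholine receptor; alpha4/beta2 (Homo sapiens); a higher number here means a weaker inhibitor, a lower number a stronger inhibitor. Compound 1 `COc1cccc(NC(=O)N[C@@H]2C3CCN(CC3)[C@@H]2Cc2cccnc2)c1` gives > 10000 nM, which is a limit of the assay rather than a number. Compound 2 `O=C(Nc1ccc(F)cc1)N[C@@H]1C2CCN(CC2)[C@@H]1Cc1cccnc1` gives > 10000 nM, also a limit. Compound 3 `O=C(Nc1cccc(F)c1)N[C@@H]1C2CCN(CC2)[C@@H]1Cc1cccnc1` gives > 10000 nM, again a limit. Because (the limit of > 10000 nM in this assay, at which 3 of the 3 values shown sit), the steps a step that the two limits leave unreadable from compound 1 to compound 2, a step that the two limits leave unreadable from compound 1 to compound 3 and a step that the two limits leave unreadable from compound 2 to compound 3 cannot be sized, and compound 3 stands only at that limit, with no number of its own. Compound 4 `Cn1cccc1C(=O)N[C@@H]1C2CCN(CC2)[C@@H]1Cc1cccnc1` has not yet been measured. The change from compound 3 to compound 4 is 1-methyl-1H-pyrrol-2-yl in place of (3-fluorophenyl)amino on a carbonyl carbon. None of the three measured steps bears on this change, and none of them has a readable size, so they offer no direction to expect. Among the compounds with values here, the only guide is that compound 3 sits at the limit, so in this assay compound 4 is expected to remain weak, with a step of an at least 1.2-fold lower number from compound 3 to compound 4 (0.09 log units; that floor lies within the scatter) that may itself turn out unreadable. The estimate for compound 4 is 8000 nM, ranging from 1500 nM to 30000 nM.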

Compound 4, inhibition constant: > 10000 nM
Compound 4: a limit, no number; the forecaster's own chance of this, stated with the estimate: 65%; middle value at least 1.2-fold (0.09 log units) away from the limit.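

Within the data shown here, no step among compound 1, compound 2, compound 3 and compound 4 can be read, because each gives only a limit rather than a number: the limit of > 10000 nM in this assay, at which 4 of the 4 values shown sit. The compounds shown leave open whether 1-methyl-1H-pyrrol-2-yl or (3-fluorophenyl)amino on the carbonyl carbon makes any difference in this assay.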